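The compounds below may be only part of what the source reports. "The series", "measured", "known", "first", "only" and "open" are said of these compounds alone.

Measured so far in an ADME assay on cells (Homo sapiens) for cytotoxicity, read by resazurin assay, with a stated time of 5 days; a higher number here means that more compound is tolerated, a lower number that less compound is tolerated:
compound 1 `COc1ccc(-c2nc(CSc3cc(C)cc(C)c3)nc3ccsc23)cn1`: > 50000 nM
compound 2 `COc1ccc(-c2nc(C(F)(F)S(=O)(=O)c3cccc(Cl)c3)nc3ccsc23)cn1`: > 50000 nM

Compound 1 `COc1ccc(-c2nc(CSc3cc(C)cc(C)c3)nc3ccsc23)cn1` gives > 50000 nM in this assay, and this is a limit of the assay rather than a number. Compound 2 `COc1ccc(-c2nc(C(F)(F)S(=O)(=O)c3cccc(Cl)c3)nc3ccsc23)cn1` gives > 50000 nM in this assay, which is also a limit and not a number. Where compound 1 stands is therefore fixed only by the limit of > 50000 nM in this assay, at which 2 of the 2 values shown sit; the two compounds cannot be ordered against each other, and nothing shows that either is tolerated more or less than the other.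

Compound 3 `COc1ccc(-c2nc(CSc3ccc(F)cc3F)nc3ccsc23)cn1` has not yet been measured. It differs from compound 1 in one place: 2,4-difluorophenyl in place of 3,5-dimethylphenyl on a sulfur. Among the compounds with values here, no step between measured compounds is available to read this change against, so the expectation rests on compound 1 alone. The step from compound 1 to compound 3 is estimated as a number no higher from compound 1 to compound 3 (the limit leaves the size open), that is, no shift beyond the scatter in either direction, with the result most likely again a limit. Compound 3 is accordingly expected to give about 50000 nM in this assay, within a range from 20000 nM to 120000 nM.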

Compound 3, half-maximal cytotoxic concentration: > 50000 nM
Compound 3: a limit, no number; the forecaster's own chance of this, stated with the estimate: 80%; the middle value sits exactly at the limit.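

Compound 3 gives > 50000 nM in this assay, which is a limit and not a number. No step from compound 1 to compound 3 can be read, because the values offer only a shared limit: the limit of > 50000 nM in this assay, at which 3 of the 3 values shown sit.

The compounds shown leave open whether compound 1, compound 2 and compound 3 differ at all in how much compound is tolerated.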